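Swapping the phenyl of compound 1 for an allyl group

This account rests on a few compounds, and the source may have more. Where it says the series, first, only, none or still open, it means among the compounds named here.

Of the compounds shown here, three sharing one core have been tested in a functional assay on MT4 cells (Homo sapiens) for inhibition; on this read-out higher numbers stand for weaker inhibition and lower numbers for stronger inhibition. Compound 1 `C/C(=C\COC(=O)Nc1ccccc1)C1=CC(=O)C(C)(C)O1` gives 103 ug/mL, the highest of the three numbers. Compound 2 `C/C(=C\COC(=O)NC(C)(C)C)C1=CC(=O)C(C)(C)O1` gives 2.1 ug/mL, and compound 3 `COc1ccc(/C=C/C=C(\C)C2=CC(=O)C(C)(C)O2)cc1` gives 5.7 ug/mL, so compound 1 stands as the weakest inhibitor in this set, with the nearest number being that of compound 3.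

The new compound 4 `C=CCNC(=O)OC/C=C(\C)C1=CC(=O)C(C)(C)O1` differs from compound 1 by one change: allyl in place of phenyl on an amide-type nitrogen. Among the compounds with values here, only one measured step bears directly on this position: a 49-fold lower number from compound 1 to compound 2 (1.69 log units; beyond the scatter). That step also replaced the phenyl on the amide-type nitrogen with a group of no ring, and it gave a large improvement. Allyl is likewise a small chain without a ring, so a step in the same direction, lowering the number beyond the scatter, is expected for compound 4, though its size need not match that of tert-butyl. The estimate for compound 4 in this assay is 10 ug/mL, with a range from 3 ug/mL to 40 ug/mL, which corresponds to an expected step of a 10-fold lower number from compound 1 to compound 4 (1.01 log units; beyond the scatter).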

Compound 4, half-maximal inhibitory concentration: 2.8 ug/mL
The estimate for compound 4 lay 3.6-fold (0.55 log units) above the measured number; the whole stated range lies above it.
By their numbers in this assay, from the lowest: compounds 2 and 4 (each within the scatter of the next); then compound 3; then compound 1.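

In this assay allyl also brings a large gain over phenyl on the amide-type nitrogen (a 37-fold lower number from compound 1 to compound 4 (1.57 log units; beyond the scatter)). The earlier step with tert-butyl therefore does not stand alone: among these compounds, both groups without a ring give far lower numbers than phenyl. Allyl and tert-butyl cannot be told apart here (a 1.3-fold higher number from compound 2 to compound 4 (0.12 log units; within the scatter)), so a double bond in place of a branched chain makes no visible difference at this position. Nothing measured explains the gap between phenyl and these two groups.

Still open, on these data alone, is whether the ring itself matters or only its aromatic kind, which cyclohexyl would address. It is also unclear whether benzyl, a longer chain such as hexyl, or a chain ending in an amine would keep numbers this low.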